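Swapping hydroxy for amino on a saturated ring carbon

This account rests on a few compounds, and the source may have more. Where it says the series, first, only, none or still open, it means among the compounds named here.

Measured so far in an ADME assay on the whole organism (Mus musculus, strain BALB/c) for pharmacokinetics, at a dose of 5 mg/kg by the intravenous route; a lower number here means slower removal, a higher number faster removal of the compound
compound 1 `Cc1cc(-c2cnc(OCC34CCC(N)(CC3)CC4)c(C)c2)c2cnn(C)c2n1` gives 44 mL/min/kg
compound 2 `Cc1cc(-c2nn(C)c3nc(N)ncc23)cnc1OCC12CCC(N)(CC1)CC2` gives 96 mL/min/kg
compound 3 `Cc1cc(-c2ccnc3[nH]ncc23)cnc1OCC12CCC(O)(CC1)CC2` gives 11 mL/min/kg

Compound 3 has the lowest number of the three, and its gaps to compound 1 and compound 2 both lie beyond the scatter. Compound 4 `Cc1cc(-c2ccnc3[nH]ncc23)cnc1OCC12CCC(N)(CC1)CC2` differs from compound 3 in one place: amino in place of hydroxy on a saturated ring carbon. Among the compounds with values here, no measured pair shows this change alone. Compound 1 (44 mL/min/kg) and compound 2 (96 mL/min/kg) both carry amino on other cores, and both stand above compound 3 (11 mL/min/kg). A rise beyond the scatter is therefore expected in this assay as an estimated step (a 3.6-fold higher number from compound 3 to compound 4 (0.56 log units; beyond the scatter)). Compound 4 is estimated at 40 mL/min/kg (range 18 mL/min/kg to 90 mL/min/kg).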

Compound 4, clearance: 23 mL/min/kg
Compound 4: the middle estimate sits 1.7-fold (0.24 log units) above what was measured; the measured number falls inside the stated range.
By their numbers in this assay, from the lowest: compound 3; then compounds 4 and 1 (each within the scatter of the next); then compound 2.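

Within the data shown here, with only this one group changed on a shared core, the swap can now be read on its own in this assay: amino in place of hydroxy gives a modest rise (a 2.1-fold higher number from compound 3 to compound 4 (0.32 log units; beyond the scatter)). The earlier amino compounds also differed from compound 3 in their cores, so they could not isolate this change. Nothing available explains the rise.

Going by these compounds, whether the step holds on other cores stays open, since compound 1 and compound 2 have no hydroxy partners here. On these data alone, how a methoxy or methylamino group on the same ring carbon would compare also remains unknown.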